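This account rests on a few compounds, and the source may have more. Where it says the series, first, only, none or still open, it means among the compounds named here.

Notes on the series. Compound 3, `COc1ccc(/C=C2\CCC/C(=C\c3cccc(Br)c3)C2=O)cc1OC`, shares its core with compound 1, `COc1cccc(/C=C2\CCC/C(=C\c3cccc(OC)c3OC)C2=O)c1`, and compound 2, `COc1cccc(/C=C2\CCC/C(=C\c3cc(OC)c(OC)c(OC)c3)C2=O)c1OC`. In an ADME assay on NHDF cells (Homo sapiens) for cytotoxicity, read by MTT assay, with a stated time of 72 h (on this read-out higher numbers stand for weaker inhibition and lower numbers for stronger inhibition), compound 1 gives 16400 nM, compound 2 gives 7900 nM, and compound 3 gives 12400 nM. Compound 3 stands second highest of the three numbers; its nearest neighbour is compound 1, whose number lies within the scatter of it, and its furthest is compound 2, whose number also lies within the scatter, so the three measured compounds are not separated on this read-out.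

Compound 4, `COc1cc(/C=C2\CCC/C(=C\c3ccc(OC)c(OC)c3)C2=O)ccc1O`, has not yet been measured. It differs from compound 3 in one place: 4-hydroxy-3-methoxyphenyl in place of 3-bromophenyl on a double-bonded chain carbon bound to a double-bonded ring carbon. Among the compounds with values here, no step between measured compounds that differ in one place is available, so the weight of this change cannot be read from the data; the only guide is that the three measured numbers fall close together. In this assay a step of a 1.1-fold higher number from compound 3 to compound 4 (0.05 log units; within the scatter) is expected, small and probably not beyond the scatter, leaning if anything toward a higher number. Compound 4 is accordingly estimated at 14000 nM, with a range from 5500 nM to 36000 nM.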

Compound 4, half-maximal inhibitory concentration: 13700 nM
The estimate for compound 4 lay 1.0-fold (0.01 log units) above the measured number; the range from low to high includes it.
By their numbers in this assay, from the lowest: compounds 2, 3, 4 and 1 (each within the scatter of the next, the first and the last beyond it).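

In this assay, within the data shown here, this is the first step that can be read at one place: a 1.1-fold higher number from compound 3 to compound 4 (0.04 log units; within the scatter) lies within the scatter, with 4-hydroxy-3-methoxyphenyl in place of 3-bromophenyl on a double-bonded chain carbon bound to a double-bonded ring carbon. The earlier compounds shown here could not show this, as none of them differ in one place; here, an exchange that removes the bromine and brings in a hydrogen-bond donor and hydrogen-bond acceptors leaves compound 4 unresolved from compound 3 on this read-out. Nothing at hand bears on why this exchange gives a step of this size.

As far as these compounds go, whether this place tolerates other kinds of group just as evenly stays open, for instance an amine or a carboxylic acid on the phenyl ring in place of 3-bromophenyl. Also open, from the compounds shown here alone, is how the hydroxy and the methoxy of 4-hydroxy-3-methoxyphenyl would each read alone, and whether the same exchange would give a step of similar size on compound 1 or compound 2.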